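A few compounds are considered here, and "the series" means these few. Any claim that something is new, unique, unknown or untested is made for them only; others in the source may bear on it.

Working notes on the series. Compound 1 `COc1ccc(OC)c(S(=O)(=O)NC(=O)c2ccc(Cn3ccc4ccc(NC(=O)CC5CCCC5)cc43)c(OC)c2)c1` is one of two compounds with a number in a functional assay (trachea) for antagonist activity, with Cavia porcellus as the target; a higher number here means a more potent compound, by a factor of ten per unit of this negative logarithm, a lower number a less potent compound. In this assay compound 1 gives 9.1, the lower of the two values. The other measured compound, compound 2 `COc1cc(C(=O)NS(=O)(=O)c2ccccc2)ccc1Cn1ncc2ccc(NC(=O)CC3CCCC3)cc21`, carries a different core and a different sulfonyl substituent, and in this assay compound 2 gives 10.5, a higher number, beyond the scatter. Among the measured compounds shown here, no single-change step between measured compounds is available, so the two values show only that the series spans a wide range.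

Compound 3 `COc1cc(C(=O)NS(=O)(=O)c2cccs2)ccc1Cn1ccc2ccc(NC(=O)CC3CCCC3)cc21` is not yet measured. Its change from compound 1 is thiophen-2-yl in place of 2,5-dimethoxyphenyl on a sulfonyl sulfur. For the measured compounds named here, no measured pair isolates a change at the sulfonyl substituent, so no size or direction can be read off. Compound 3 is expected to give 9.3, between 8.6 and 10.1. The estimated step of a number 0.20 log units higher from compound 1 to compound 3 (within the scatter) is small, close to none beyond the scatter.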

Compound 3, negative logarithm of the antagonist equilibrium constant: 9.6
Compound 3: middle estimate off by 0.30 log units, on the low side; low and high end bracket the measured number.
By their numbers in this assay, from the lowest: compound 1; then compound 3; then compound 2.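

The sulfonyl substituent now has its first single-change reading: in this assay, thiophen-2-yl in place of 2,5-dimethoxyphenyl on a sulfonyl sulfur gives a number 0.50 log units higher from compound 1 to compound 3 (beyond the scatter). The position therefore affects potency, and the 2,5-dimethoxyphenyl group with its 10 heavy atoms is not needed to reach this level, as the 5-heavy-atom thiophen-2-yl does better on the shared core. No measurement at hand accounts for this step.

This single step cannot separate the effect of changing the aromatic ring from that of removing the two methoxy groups. It also leaves open how a non-aromatic group on the sulfonyl sulfur, such as a butyl chain or a cyclopropyl ring, would compare with thiophen-2-yl.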